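The source may hold more compounds than are shown below. What is called first, only, known or untested is meant among the compounds shown, and "the series" means these compounds.

Of the compounds shown here, two with a shared core have been tested so far. Compound 1 `O=[N+]([O-])c1cc(-c2nnn(Cc3ccc(Br)cc3)n2)cc([N+](=O)[O-])c1` gives 55000 nM in an ADME assay on CHO-K1 cells (Cricetulus griseus) for cytotoxicity, read by MTT assay, with a stated time of 24 h (on this read-out higher numbers stand for weaker inhibition and lower numbers for stronger inhibition), and compound 2 `O=[N+]([O-])c1cc(-c2nnn(Cc3ccc(F)cc3)n2)cc([N+](=O)[O-])c1` gives 35000 nM. Among the measured compounds shown here, the only step between them, a 1.6-fold lower number from compound 1 to compound 2 (0.20 log units; within the scatter), shows that swapping one halogen for another on the pendant ring barely moved the number. On these two numbers compound 2 holds the lowest value, but its gap to compound 1 is within the scatter, so no order can be read from it.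

Compound 3 `COc1cccc(Cn2nnc(-c3cc([N+](=O)[O-])cc([N+](=O)[O-])c3)n2)c1` has not yet been measured. It differs from compound 2 in one place: 3-methoxyphenyl in place of 4-fluorophenyl on a saturated chain carbon bound to an aromatic nitrogen. For the measured compounds named here, the only relevant precedent is the change at the same pendant ring from compound 1 to compound 2, which stayed within the scatter. By that precedent, the step from compound 2 to compound 3 is expected to be small, around a 1.1-fold higher number from compound 2 to compound 3 (0.06 log units; within the scatter), with no clear direction. Compound 3 is therefore estimated at 40000 nM in this assay, in a range from 15000 nM to 100000 nM.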

Compound 3, half-maximal inhibitory concentration: > 100000 nM
Compound 3: a limit, no number; the forecaster's own chance of this, stated with the estimate: 20%; middle value at least 2.5-fold (0.39 log units) away from the limit.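

For compound 3 the read-out is a limit of the assay, not a number: the limit of > 100000 nM in this assay, at which 1 of the 3 values shown sits. Even so, the step of an at least 2.8-fold higher number from compound 2 to compound 3 (0.45 log units; beyond the scatter) is the first one at this position to clear the scatter, showing that the group on the saturated chain carbon bound to an aromatic nitrogen can shift this read-out towards weaker inhibition, which the exchange of one halogen for another did not show. The other step, an at least 1.8-fold higher number from compound 1 to compound 3 (0.25 log units; that floor lies within the scatter), gives no firm order, and neither step has a known upper size.

The compounds shown cannot separate the effect of the methoxy group from that of its place on the ring, which a 4-methoxyphenyl or a 3-fluorophenyl group would help to do. Going by these compounds, how an amine or a carboxylic acid on this ring would read also remains open.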